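Amide variation on the carbonyl carbon: compound 4

The source may report more compounds than this note shows. Statements on the series, on what has been measured and on what is new or still open speak of the compounds shown alone.

Measured in a functional assay on the whole organism with Rattus norvegicus as the target, at a dose of 20 mg/kg by the oral route; a lower number here means less inhibition, a higher number more inhibition at the dose given (going by the name of the read-out):
compound 1 `CCNC(=O)/C=C1\CCc2ccc(F)cc21`: 45%
compound 2 `CC(C)NC(=O)/C=C1\CCc2ccc(F)cc21`: 45%
compound 3 `O=C(/C=C1\CCc2ccc(F)cc21)N1CCCC1`: 10%

Compound 3 stands lowest of the three numbers; its nearest neighbour is compound 1 and its furthest compound 2, both beyond the scatter. Compound 4 `O=C(/C=C1\CCc2ccc(F)cc21)NC1CCC1` differs from compound 3 by cyclobutylamino in place of pyrrolidin-1-yl on a carbonyl carbon. Going by the values given here, the steps that bear on this are a number 35 percentage points lower from compound 1 to compound 3 (beyond the scatter) and a number 35 percentage points lower from compound 2 to compound 3 (beyond the scatter): in both, pyrrolidin-1-yl on the carbonyl carbon went with a large fall against ethylamino or isopropylamino, while no change at the digits printed from compound 1 to compound 2 (within the scatter) shows that exchanging ethylamino for isopropylamino changed nothing. Restoring an amino group of the cyclobutylamino kind is therefore expected to reverse most of that fall, a number 32 percentage points higher from compound 3 to compound 4 (beyond the scatter). Compound 4 is estimated at 42%, in the range 25% to 60%.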

Compound 4, a percentage reported as inhibition, in the whole organism at one dose (the size of the read-out at that dose, not a potency): 4%
Compound 4: middle estimate off by 38 percentage points, on the high side, outside the stated range (below it).
By their numbers in this assay, from the lowest: compounds 4 and 3 (each within the scatter of the next); then compounds 1 and 2 (each within the scatter of the next).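

At this carbonyl carbon, a hydrogen-bond donor on the group does not suffice in this assay: cyclobutylamino has one and pyrrolidin-1-yl none, yet the exchange gives a number 6 percentage points lower from compound 3 to compound 4 (within the scatter). Cyclobutyl on the amide-type nitrogen does not match the open chains, with a number 41 percentage points lower from compound 1 to compound 4 (beyond the scatter) and a number 41 percentage points lower from compound 2 to compound 4 (beyond the scatter), so both ring-bearing compounds sit low and both open-chain compounds high. Nothing measured here accounts for this.

From the compounds shown here alone, whether cyclopropyl or a longer chain such as n-butyl on that nitrogen would follow the open-chain compounds or the ring-bearing ones remains open. A single oral dose also leaves open how these numbers would move at other doses.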